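The source may report more compounds than this note shows. Statements on the series, on what has been measured and on what is new or still open speak of the compounds shown alone.

Measured so far in a functional assay on the whole organism (strain Wistar) with Rattus norvegicus as the target, with a stated time of 15 days, at a dose of 10 mg/kg by the oral route; on this read-out lower numbers stand for a weaker effect and higher numbers for a stronger effect at the one dose given:
compound 1 `O=C1NC(=O)/C(=C/c2ccc(OCCSc3nnc(-c4ccccc4)[nH]3)cc2)S1` gives 19.2%;
compound 2 `O=C1NC(=O)/C(=C/c2ccc(OCCSc3nnc(Cc4ccccc4)[nH]3)cc2)S1` gives 22.8%;
compound 3 `O=C1NC(=O)/C(=C/c2ccc(OCCSc3nnc(-c4ccccc4)o3)cc2)S1` gives 22.2%.

Compound 1 and compound 2 share a core and differ by benzyl in place of phenyl on an aromatic carbon; the step is a number 3.6 percentage points higher from compound 1 to compound 2 (within the scatter). Compound 3 carries a different core; the difference between the core of compound 1 and the core of compound 3 is not broken down here. Compound 4 `O=C1NC(=O)/C(=C/c2ccc(OCCSc3nnc(Cc4ccccc4)o3)cc2)S1` is not yet measured. It differs from compound 3 by benzyl in place of phenyl on an aromatic carbon, the same kind of change as from compound 1 to compound 2, but at a place on a five-membered aromatic ring with two nitrogen and one oxygen, next to the ring oxygen, rather than between two ring nitrogen atoms.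

Because the step of a number 3.6 percentage points higher from compound 1 to compound 2 (within the scatter) was within the scatter, a step of similar size is expected here, a number 2.8 percentage points higher from compound 3 to compound 4 (within the scatter). Compound 4 is estimated at 25%, between 15% and 35%.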

Compound 4, a percentage reported as activity, at one dose (the size of the read-out at that dose, not a potency): 20.5%
The estimate for compound 4 lay 4.5 percentage points above the measured number; measured number inside the range.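

In this assay, benzyl in place of phenyl on the second core gives a number 1.7 percentage points lower from compound 3 to compound 4 (within the scatter). Set beside the earlier step, the two cores do not separate on this change: the same change on two cores in this assay, a number 3.6 percentage points higher (within the scatter) from compound 1 to compound 2 and a number 1.7 percentage points lower (within the scatter) from compound 3 to compound 4, 5.3 percentage points apart, within the scatter of two such steps

This is consistent with the change behaving alike on both cores, but neither step shows that the change has any effect, so there is no measurable effect here to carry from one core to the other. The compounds shown leave open whether an amine, a carboxylic acid or a longer chain ending in phenyl at this place would move the read-out beyond the scatter on either core. With a single dose throughout, the read-out speaks only of a stronger or weaker effect at that dose.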